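Aryl Amine Swaps on a Shared Oxadiazole-Benzisothiazole Core

The source may hold more compounds than are shown below. What is called first, only, known or untested is meant among the compounds shown, and "the series" means these compounds.

Measured so far:
compound 1, `CNc1nnc(-c2nsc3ccccc23)o1`: 60%
compound 2, `Clc1ccc(Nc2nnc(-c3nsc4ccccc34)o2)cc1`: 40%

Two compounds share a core and differ only in the group on the amine nitrogen. In a functional assay on the whole organism for inhibition, with Rattus norvegicus as the target, with a stated time of 3.5 h, at a dose of 100 mg/kg by the intraperitoneal route (a lower number here means less inhibition, a higher number more inhibition at the dose given (going by the name of the read-out)), compound 1 gives 60%, and compound 2 gives 40%. Among the measured compounds shown here, the one measured step, a number 20 percentage points lower from compound 1 to compound 2 (beyond the scatter), comes with a 4-chlorophenyl in place of methyl on the nitrogen, so compound 2 stands as the lower of the two numbers, with compound 1 the higher.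

Compound 3, `COc1ccc(Nc2nnc(-c3nsc4ccccc34)o2)cc1`, keeps the aryl amine of compound 2 and changes only the substituent on the six-membered ring: methoxy in place of chloro on an aromatic carbon. For the measured compounds named here, no measured step concerns this kind of exchange; the only step in hand swaps the whole group on the nitrogen, not a substituent on the ring, so it gives no direct guide. With nothing to point either way, compound 3 is expected to sit near compound 2, with a step of about a number 5 percentage points higher from compound 2 to compound 3 (within the scatter) in this assay, inside the scatter. The estimate for compound 3 is therefore 45%, with a range from 20% to 70%.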

Compound 3, a percentage reported as inhibition, in the whole organism at one dose (the size of the read-out at that dose, not a potency): 50%
For compound 3 the middle estimate is 5 percentage points below the measured one; low and high end bracket the measured number.
By their numbers in this assay, from the lowest: compounds 2, 3 and 1 (each within the scatter of the next, the first and the last beyond it).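

Among the compounds shown here, compound 2 and compound 3 give the first look at a change on the six-membered ring itself rather than a swap of the whole group on the nitrogen. In this assay, putting methoxy in place of chloro on this aromatic carbon, para to a large group, gives a number 10 percentage points higher from compound 2 to compound 3 (within the scatter), so at this one dose the read-out does not separate the two groups, even though methoxy brings a hydrogen-bond acceptor that chloro does not have. No measurement shown here offers a reason for this result, so the comparison stays a plain observation about these two compounds.

The compounds shown leave open whether a clearly different group at this place on the ring, such as an amine or a carboxylic acid, would give a step beyond the scatter, and how a plain phenyl ring with only hydrogen there would compare with compound 2 and compound 3. Also open, from the compounds shown here alone, is what a longer chain, such as propyl, would do in place of the methyl on the nitrogen of compound 1.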